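A few compounds are considered here, and "the series" means these few. Any claim that something is new, unique, unknown or untested is made for them only; others in the source may bear on it.

The measured compounds and their values in a functional assay on CHO cells for antagonist activity at metabotropic glutamate receptor 5 (Rattus norvegicus), read by calcium flux; on this read-out lower numbers stand for stronger inhibition and higher numbers for weaker inhibition:

compound 1, `COc1cc(OC)cc(-c2ccc3cccnc3n2)c1`: 67 nM
compound 2, `Cc1ccc(-c2ccc3cccnc3n2)cc1C`: 45 nM
compound 3, `Cc1cccc(-c2cc3ncccc3cn2)c1`: 1270 nM

Compound 1 stands second highest of the three numbers. Its nearest neighbour is compound 2, whose number is lower but still within the usual scatter of repeated measurements, so the two cannot be told apart. The furthest is compound 3, whose number lies well beyond the scatter above that of compound 1; compound 3 also carries a different substitution pattern on the pendant ring and a differently arranged fused core, so several things change at once between it and compound 1.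

The unmeasured compound 4, `COc1cc(OC)cc(-c2ccc3ccc(C)nc3n2)c1`, keeps the dimethoxyphenyl group and the fused core of compound 1 and differs from it in a single place: methyl in place of hydrogen on an aromatic carbon.

Going by the values given here, no pair of measured compounds shows exactly this change, so there is no measured step to lean on. A single small methyl added in this way is expected to move the number little, and the estimated step from compound 1 to compound 4 in this assay, a 1.0-fold lower number from compound 1 to compound 4 (0.01 log units; within the scatter), is expected to stay within the usual scatter in either direction. Compound 4 is therefore expected to give about 65 nM, with a range from 20 nM to 220 nM.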

Compound 4, half-maximal inhibitory concentration: 51.7 nM
Compound 4: middle estimate off by 1.3-fold (0.10 log units), on the high side; the measured number falls inside the stated range.
By their numbers in this assay, from the lowest: compounds 2, 4 and 1 (each within the scatter of the next); then compound 3.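

Going by these compounds alone, until now no two compounds in this assay differed in one place, so nothing showed what a single change does. The step of a 1.3-fold lower number from compound 1 to compound 4 (0.11 log units; within the scatter) gives the first such reading: on this aromatic carbon next to the ring nitrogen, methyl in place of hydrogen leaves the number indistinguishable from that of the parent, so this position accepts one added carbon without a change that can be told from the scatter. Nothing measured here explains this outcome, and the step alone cannot say whether the methyl has no influence at this position or whether opposing influences happen to cancel.

The compounds shown carry only hydrogen and methyl at this position, so it remains open what a longer chain such as propyl, an amine or a carboxylic acid on the same carbon would do to the number. From the compounds shown here alone, it also remains open whether the same methyl would give a similar step with the pendant ring of compound 2 or on the differently arranged core of compound 3.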